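A few compounds are considered here, and "the series" means these few. Any claim that something is new, unique, unknown or untested is made for them only; others in the source may bear on it.

Measured so far:
compound 1 `CSc1ccccc1NC(=O)Nc1cc(C)nc2ccccc12`: > 25000 nM
compound 2 `COC(=O)c1cccc(NC(=O)Nc2cc(C)nc3ccccc23)c1`: 26000 nM

In an ADME assay on HEK293 cells (Homo sapiens) for cytotoxicity, with a stated time of 72 h (on this read-out lower numbers stand for an effect already at smaller amounts and higher numbers for an effect only at larger amounts of compound), compound 1 gives only a limit, > 25000 nM, not a number, so where it stands is known only as the limit of > 25000 nM in this assay, at which 1 of the 2 values shown sits. In this assay compound 2 gives 26000 nM. Compound 3 `Cc1cc(NC(=O)Nc2ccccc2[N+](=O)[O-])c2ccccc2n1` is not yet measured; it differs from compound 1 by nitro in place of methylsulfanyl on an aromatic carbon. Among the compounds with values here, no measured step between two compounds is available to lean on, so the step expected in this assay is none beyond the usual scatter. Compound 3 is estimated at 25000 nM, with a range from 10000 nM to 60000 nM, which means an expected step of a number no higher from compound 1 to compound 3 (the limit leaves the size open).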

Compound 3, half-maximal effective concentration: > 25000 nM
Compound 3 gave a limit, no number (the forecaster's own chance of this, stated with the estimate: 60%); the middle value lies on the limit itself.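

Compound 1 and compound 3 each give only a limit, not a number, in this assay, so no step between them can be read: the limit of > 25000 nM in this assay, at which 2 of the 3 values shown sit.

As far as these compounds go, whether nitro in place of methylsulfanyl changes the read-out at all stays open.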